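A few compounds are considered here, and "the series" means these few. Any claim that something is new, unique, unknown or untested is made for them only; others in the source may bear on it.

- compound 1 `COc1ccc(-c2nc(C)nn2-c2cccc(C(=O)NCCCOc3ccccc3)c2)cc1` gives 3560 nM 
- compound 2 `CCc1nc(-c2ccc(OC)cc2)n(-c2cccc(C(=O)NCCCCc3ccccc3)c2)n1` gives 180 nM 

In a functional assay on PANC-1 cells (Homo sapiens), read by microscopy, crystal violet staining and transwell migration, with a stated time of 18 h, in the presence of a further agent that is not named here (a lower number here means a stronger inhibitor, a higher number a weaker inhibitor), compound 2 has the lower of the two numbers, and its gap to compound 1 lies beyond the scatter. Compound 3 `CCc1nc(-c2ccc(OC)cn2)n(-c2cccc(C(=O)NCCCCc3ccccc3)c2)n1` is compound 2 with 5-methoxypyridin-2-yl in place of 4-methoxyphenyl on an aromatic carbon and nothing else altered. Among the compounds with values here, no measured pair shows this swap, so in this assay only a modest move toward a weaker inhibitor is expected, possibly none beyond the scatter. An estimated 1.9-fold higher number from compound 2 to compound 3 (0.29 log units; within the scatter) is expected. By estimate compound 3 gives 350 nM with 100 nM to 1200 nM as the expected range.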

Compound 3, half-maximal inhibitory concentration: 150 nM
Compound 3: the middle estimate sits 2.3-fold (0.37 log units) above what was measured; the range from low to high includes it.
By their numbers in this assay, from the lowest: compounds 3 and 2 (each within the scatter of the next); then compound 1.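

In this assay, 5-methoxypyridin-2-yl in place of 4-methoxyphenyl gives a 1.2-fold lower number from compound 2 to compound 3 (0.08 log units; within the scatter). On this aromatic carbon of the five-membered ring, the swap to a ring with 1 hetero atom and 2 hydrogen-bond acceptors therefore leaves the number unchanged within the scatter. Nothing measured here gives a reason for this result.

On these data alone, it remains open how an amine or a carboxylic acid in place of the methoxy group would read. Compound 1 differs from compound 2 in more than one place, so the gap between them cannot be assigned to either the ethyl group or the chain on the amide.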